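Trading ethoxycarbonyl for nitro on the shared core

The source may hold more compounds than are shown below. What is called first, only, known or untested is meant among the compounds shown, and "the series" means these compounds.

In a functional assay on the whole organism (strain Sprague-Dawley) for inhibition, with Rattus norvegicus as the target, with a stated time of 10 min (on this read-out higher numbers stand for an effect only at larger amounts of compound and lower numbers for an effect already at smaller amounts), compound 3 `CCOC(=O)c1ccc(OCC)c(-c2ncc(C(=O)OCC)c(=O)[nH]2)c1` gives 1 mg/kg. Compound 2 `CCOC(=O)c1cnc(-c2ccccc2OCC)[nH]c1=O` has hydrogen where compound 3 has ethoxycarbonyl. Compound 2 gives 2 mg/kg, and the two values count as level. Compound 1 `CCOc1ccc([N+](=O)[O-])cc1-c1ncc(C(=O)O)c(=O)[nH]1` gives a clearly higher number, 25 mg/kg, so it needs a much larger dose for the same effect. Compound 1 also carries a nitro group, but it differs from compound 3 elsewhere as well, so it gives no clean measure of nitro alone.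

Compound 4 `CCOC(=O)c1cnc(-c2cc([N+](=O)[O-])ccc2OCC)[nH]c1=O` is compound 3 with one change, nitro in place of ethoxycarbonyl on an aromatic carbon, para to an ethoxy group. Among the measured compounds shown here, the only measured step at this carbon is a 2.0-fold lower number from compound 2 to compound 3 (0.30 log units; within the scatter). On that evidence, no shift beyond the scatter is expected in this assay when the group there is replaced, and no direction can be firmly expected. The estimated step is a 1.5-fold higher number from compound 3 to compound 4 (0.18 log units; within the scatter). For compound 4 the expected value is 1.5 mg/kg, with an estimated range of 0.5 mg/kg to 5 mg/kg.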

Compound 4, dose for 50% inhibition: 5 mg/kg
Compound 4: middle estimate off by 3.3-fold (0.52 log units), on the low side, within the range that was stated.
By their numbers in this assay, from the lowest: compounds 3 and 2 (each within the scatter of the next); then compound 4; then compound 1.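

At this carbon the choice of group now shows up beyond the scatter in this assay: nitro in place of ethoxycarbonyl gives a 5.0-fold higher number from compound 3 to compound 4 (0.70 log units; beyond the scatter) and nitro in place of hydrogen gives a 2.5-fold higher number from compound 2 to compound 4 (0.40 log units; beyond the scatter), so nitro calls for a larger dose than either of the other two groups, which stand level with each other. With nitro kept on the ring, the other end of the molecule matters too, since ethyl in place of hydrogen on an oxygen next to a carbonyl group gives a 5.0-fold lower number from compound 1 to compound 4 (0.70 log units; beyond the scatter) in the same test. Nothing measured here explains these shifts.

From the compounds shown here alone, whether an amine or a nitrile at this carbon would match hydrogen and ethoxycarbonyl or fall with nitro stays open. So does the effect of a longer chain in place of that ethyl.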